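Swapping the Side Ring on Compound 3

The source may report more compounds than this note shows. Statements on the series, on what has been measured and on what is new or still open speak of the compounds shown alone.

Measured in an ADME assay on Caco-2 cells (Homo sapiens) for permeability; on this read-out lower numbers stand for lower permeability and higher numbers for higher permeability:
- compound 1 `NC(=O)c1nn(-c2ccc3onc(N)c3c2)c2c(F)c(-c3ccc(N4CCCCC4=O)cc3F)ccc12` gives 3.04 10^-6 cm/s
- compound 2 `CN(C)Cc1nccn1-c1ccc(-c2ccc3c(C(N)=O)nn(-c4ccc5onc(N)c5c4)c3c2F)c(F)c1` gives 2.03 10^-6 cm/s
- compound 3 `CN(C)Cc1[nH]ncc1-c1ccc(-c2ccc3c(C(N)=O)nn(-c4ccc5onc(N)c5c4)c3c2F)c(F)c1` gives 1.1 10^-6 cm/s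

Compound 3 sits at the low end of these numbers, within the scatter of compound 2 and apart only from compound 1. Compound 4 `CN(C)Cc1cnccc1-c1ccc(-c2ccc3c(C(N)=O)nn(-c4ccc5onc(N)c5c4)c3c2F)c(F)c1` is next, with this change: 3-((dimethylamino)methyl)pyridin-4-yl in place of 5-((dimethylamino)methyl)-1H-pyrazol-4-yl on an aromatic carbon. In words, 3-((dimethylamino)methyl)pyridin-4-yl takes the place of 5-((dimethylamino)methyl)-1H-pyrazol-4-yl on an aromatic carbon. The closest measured swap, between two rings carrying the same side chain, gave a 1.8-fold lower number from compound 2 to compound 3 (0.27 log units; within the scatter) and stayed within the scatter. Replacing 2-oxopiperidin-1-yl gave a 2.8-fold lower number from compound 1 to compound 3 (0.44 log units; beyond the scatter), a modest step beyond it. In this assay no step beyond the scatter is therefore expected, and the estimate is a 1.5-fold higher number from compound 3 to compound 4 (0.16 log units; within the scatter) in the upward direction. For compound 4 the estimated value is 1.6 10^-6 cm/s, with an expected range from 0.7 10^-6 cm/s to 3.5 10^-6 cm/s.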

Compound 4, apparent permeability: 6.69 10^-6 cm/s
Beside the measured number, compound 4's estimate is 4.2-fold (0.62 log units) below it; the measured number lies above the stated range.
By their numbers in this assay, from the lowest: compounds 3, 2 and 1 (each within the scatter of the next, the first and the last beyond it); then compound 4.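

In this assay, the ring carrying the side chain at this position can move the number beyond the scatter: the six-membered 3-((dimethylamino)methyl)pyridin-4-yl gives higher numbers than either five-membered ring (a 6.1-fold higher number from compound 3 to compound 4 (0.78 log units; beyond the scatter); a 3.3-fold higher number from compound 2 to compound 4 (0.52 log units; beyond the scatter)). It also exceeds the 2-oxopiperidin-1-yl group (a 2.2-fold higher number from compound 1 to compound 4 (0.34 log units; beyond the scatter)), so carrying a dimethylaminomethyl side chain does not by itself tie a compound to the lower numbers. No measurement here gives a reason for these steps.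

From the compounds shown here alone, it remains open whether a phenyl ring bearing the same side chain would match the pyridine. A pyridine carrying a morpholinomethyl chain would show whether the dimethylamino group matters.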